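Swapping the acyl aryl group on a thiosemicarbazide series

The source may hold more compounds than are shown below. What is called first, only, known or untested is meant among the compounds shown, and "the series" means these compounds.

Of the compounds shown here, two of a shared core have been measured so far. Compound 1 `COc1cc2ncnc(NNC(=S)NC(=O)c3ccccc3)c2cc1OC` gives 8180 nM in a functional assay on CNE-2 cells (Homo sapiens) for cytotoxicity, read by MTT assay, with a stated time of 72 h; a lower number here means a stronger inhibitor, a higher number a weaker inhibitor. Compound 2 `O=C(NC(=S)NNc1ncnc2ccccc12)c1ccc(Cl)cc1` gives 1530 nM in this assay, the lower of the two numbers, standing a step beyond the scatter from compound 1. The next compound, compound 3 `Cc1ccccc1C(=O)NC(=S)NNc1ncnc2ccccc12`, has not yet been measured. It differs from compound 2 at a single place: 2-methylphenyl in place of 4-chlorophenyl on a carbonyl carbon. Within the data shown here, nothing measured so far speaks to what the 2-methylphenyl group does on this carbonyl carbon, so the step is expected to be small, with a modest drift toward a higher number, within or just beyond the scatter, as a 1.6-fold higher number from compound 2 to compound 3 (0.21 log units; within the scatter) expresses. On that basis compound 3 is estimated to give 2500 nM in this assay, with the likely range running from 800 nM to 8000 nM.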

Compound 3, half-maximal inhibitory concentration: 5460 nM
Compound 3: middle estimate off by 2.2-fold (0.34 log units), on the low side; measured number inside the range.
By their numbers in this assay, from the lowest: compound 2; then compounds 3 and 1 (each within the scatter of the next).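

Among these compounds, on this carbonyl carbon the aryl group is not interchangeable: in this assay, 2-methylphenyl in place of 4-chlorophenyl gives a 3.6-fold higher number from compound 2 to compound 3 (0.55 log units; beyond the scatter), the first step in this set that can be read at a single place. The two groups match in heavy-atom count, in their one six-membered aromatic ring of carbon only and in having no hydrogen-bond donors or acceptors, so these counts do not separate them, although the number moves beyond the scatter. Nothing measured here accounts for the step.

Among the compounds shown here, compound 1 differs from compound 2 and compound 3 in more than one place, so no steps to it can be read. From the compounds shown here alone, whether the chlorine or the methyl carries the difference stays open, as does what a methoxyphenyl group or a longer alkyl chain would give on this carbonyl carbon.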